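Permeability notes: cyano to fluoro on the benzyl arm

The source may report more compounds than this note shows. Statements on the series, on what has been measured and on what is new or still open speak of the compounds shown alone.

Compound 1 `COc1ccc(F)cc1CNCCCNc1ccnc2cc(Cc3ccc(C#N)cc3)ccc12` sits level with the two other measured members of the series. In an ADME assay for permeability, using PAMPA, with a stated time of 30 min, at pH 7.4 (a higher number here means that the compound crosses the layer faster, a lower number that the compound crosses the layer more slowly), compound 1 gives 23 10^-6 cm/s, compound 2 `CC(C)CCc1ccc2c(NCCCNCc3ccco3)ccnc2c1` gives 23 10^-6 cm/s, and compound 3 `COc1cccc(CNCCCNc2ccnc3cc(Cc4ccc(C#N)cc4)ccc23)c1O` gives 23 10^-6 cm/s; all three values lie within the scatter of one another, so no order among them can be read.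

The next compound is compound 4 `COc1ccc(F)cc1CNCCCNc1ccnc2cc(Cc3ccc(F)cc3)ccc12`, which differs from compound 1 only in the change (fluoro in place of cyano on an aromatic carbon). Among the compounds with values here, no measured step touches this exact exchange. Within the data shown here, the one step that can be compared is no change at the digits printed from compound 1 to compound 3 (within the scatter), which shows that swapping one substituted aryl group for another on the saturated chain carbon bound to an amine nitrogen left this assay unmoved. On that basis, the expected step of a 1.1-fold higher number from compound 1 to compound 4 (0.05 log units; within the scatter) is none beyond the scatter, with any drift more likely upward than downward. Compound 4 is therefore estimated at 26 10^-6 cm/s, expected to fall between 15 10^-6 cm/s and 42 10^-6 cm/s.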

Compound 4, apparent permeability: 23 10^-6 cm/s
The estimate for compound 4 lay 1.1-fold (0.05 log units) above the measured number; the range from low to high includes it.
By their numbers in this assay, from the lowest: compounds 1, 2, 3 and 4 (each within the scatter of the next).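

Fluoro in place of cyano on the aromatic carbon gives no change at the digits printed from compound 1 to compound 4 (within the scatter) in this assay, the first direct reading at this position. The earlier step concerned the aryl group on the saturated chain carbon, whereas this one concerns the 4-cyanobenzyl arm at the other end of the molecule. At this position, going from two heavy atoms to one and from one hydrogen-bond acceptor to none brings no shift beyond the scatter.

With only cyano and fluoro shown here, the compounds leave open whether a primary amine, a carboxylic acid or a longer chain at this position would also stay within the scatter of compound 1. Nothing available explains the unchanged read-out.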